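Swapping the aryl group on the ring nitrogen

A few compounds are considered here, and "the series" means these few. Any claim that something is new, unique, unknown or untested is made for them only; others in the source may bear on it.

The measured compounds are:
compound 1, `COc1cc2c(Oc3ccc(NC(=O)c4nn(-c5ccccc5C)cc(C)c4=O)c(F)c3)ccnc2cc1OCCCCCCC(=O)NO`, which gives 2300 nM in a functional assay on HCT-116 cells (Homo sapiens) for inhibition, read by MTT assay, with a stated time of 72 h; a lower number here means a stronger inhibitor, a higher number a weaker inhibitor;
compound 2, `COc1cc2c(Oc3ccc(NC(=O)c4nn(-c5ccc(F)c(Cl)c5)cc(C)c4=O)cc3)ccnc2cc1OCCCCCCC(=O)NO`, which gives 370 nM in this assay;
compound 3, `COc1cc2c(Oc3ccc(NC(=O)c4nn(-c5cccc(C(F)(F)F)c5)cc(C)c4=O)cc3)ccnc2cc1OCCCCCCC(=O)NO`, which gives 590 nM in this assay.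

Compound 3 stands second highest of the three numbers: compound 2 is its nearest neighbour, within the scatter, and compound 1 is the furthest, beyond the scatter.

The next compound is compound 4, `COc1cc2c(Oc3ccc(NC(=O)c4nn(-c5ccccc5C)cc(C)c4=O)cc3)ccnc2cc1OCCCCCCC(=O)NO`. Relative to compound 3 it carries 2-methylphenyl in place of 3-(trifluoromethyl)phenyl on an aromatic nitrogen. Among the compounds with values here, one measured step bears on this position: a 1.6-fold higher number from compound 2 to compound 3 (0.20 log units; within the scatter), a change of the aryl group on the same aromatic nitrogen that left the number within the scatter. Within the data shown here, no step is known between compound 4 and compound 1, which carries the same 2-methylphenyl group, so only the two values can be set side by side: compound 1 gives 2300 nM and compound 3 gives 590 nM. Among the measured compounds shown here, the single known step at this position points to little movement, while the expectation leans upward because compound 1 gives 2300 nM with the same 2-methylphenyl group. Compound 4 is expected to give 1400 nM, with a range of 500 nM to 4000 nM, an expected step of a 2.4-fold higher number from compound 3 to compound 4 (0.38 log units; beyond the scatter).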

Compound 4, half-maximal inhibitory concentration: 660 nM
Beside the measured number, compound 4's estimate is 2.1-fold (0.33 log units) above it, within the range that was stated.
By their numbers in this assay, from the lowest: compounds 2, 3 and 4 (each within the scatter of the next); then compound 1.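

On the aromatic nitrogen, two replacements by 2-methylphenyl now sit beside the earlier change of aryl group, and each stays within the scatter in this assay: in place of 3-(trifluoromethyl)phenyl (a 1.1-fold higher number from compound 3 to compound 4 (0.05 log units; within the scatter)) and in place of 3-chloro-4-fluorophenyl (a 1.8-fold higher number from compound 2 to compound 4 (0.25 log units; within the scatter)). The high number of compound 1 therefore does not go with the 2-methylphenyl group alone: with that group held constant, hydrogen in place of fluoro on an aromatic carbon gives a 3.5-fold lower number from compound 1 to compound 4 (0.54 log units; beyond the scatter), and this is the only step among those shown that lies beyond the scatter. Nothing shown here accounts for either the flat response at the nitrogen or the step at the fluoro position.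

The compounds shown leave open whether this flat response at the nitrogen would hold for an aryl group carrying an amine or a carboxylic acid, or for a plain phenyl group. Within the data shown here, they also leave open whether the fluoro on that aromatic carbon would give a step of similar size alongside 3-chloro-4-fluorophenyl or 3-(trifluoromethyl)phenyl, since it is seen only with 2-methylphenyl.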